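The source may hold more compounds than are shown below. What is called first, only, known or untested is meant among the compounds shown, and "the series" means these compounds.

Working notes on the series.

Compound 1 `CCOC(=O)c1c(-c2c(Cl)c3ccccc3oc2=O)nn(-c2cccc(C)c2)c1C(=O)OCC` gives 36000 nM in a functional assay on A549 cells (Homo sapiens) for cytotoxicity, read by MTT assay, with a stated time of 48 h; a lower number here means a stronger inhibitor, a higher number a weaker inhibitor. Compound 2 `CCOC(=O)c1c(-c2cc3ccccc3oc2=O)nn(-c2cccc(C)c2)c1C(=O)OCC` gives 52000 nM in this assay. Compound 3 `COC(=O)c1c(-c2cc3ccccc3oc2=O)nn(-c2cccc(Cl)c2)c1C(=O)OC` gives 30000 nM in this assay. Compound 2 sits at the upper end of the three numbers, but its gaps to compound 1 and to compound 3 are both within the scatter, so the three compounds are not distinguished by this assay. Going by the values given here, the one single-point step that has been measured, a 1.4-fold higher number from compound 1 to compound 2 (0.16 log units; within the scatter), is within the scatter.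

Compound 4 `CCOC(=O)c1c(-c2cc3ccccc3oc2=O)nn(-c2cccc(F)c2)c1C(=O)OCC` has not been measured. The change from compound 2 is fluoro in place of methyl on an aromatic carbon. Among the compounds with values here, no measured step touches this position: the step from compound 1 to compound 2 concerns the chloro on the other ring system, and compound 3 differs from compound 2 in two places at once, so its value shows only that a chloro-bearing phenyl with methyl esters lands within the scatter of compound 2. With nothing pointing either way, no step beyond the scatter is expected for compound 4, the expected step being a 1.2-fold lower number from compound 2 to compound 4 (0.06 log units; within the scatter). Compound 4 is therefore estimated at 45000 nM, with a range from 18000 nM to 110000 nM.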

Compound 4, half-maximal inhibitory concentration: 59000 nM
Estimate against measurement, compound 4: 1.3-fold (0.12 log units) below, and the stated range covers the measured number.
By their numbers in this assay, from the lowest: compounds 3, 1, 2 and 4 (each within the scatter of the next).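

Going by these compounds alone, this is the first measured step at this position: on an aromatic carbon meta to a large group, fluoro in place of methyl gives a 1.1-fold higher number from compound 2 to compound 4 (0.05 log units; within the scatter) in this assay. The two groups are therefore not distinguished here, and the pair gives no sign that this assay responds to the change from 3-methylphenyl to 3-fluorophenyl. No evidence is at hand on what lies behind this result.

Within the data shown here, the pair covers only two small groups of one heavy atom each, so it remains open whether an amine, a carboxylic acid or a longer chain at the same place would give a step beyond the scatter. Among these compounds, with only this pair at the position, no trend across substituents can be read from it.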